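A Larger Amide on the Carbonyl Carbon

The compounds below may be only part of what the source reports. "The series", "measured", "known", "first", "only" and "open" are said of these compounds alone.

Measured in an ADME assay on MDCKII-LE cells (Canis lupus familiaris) for permeability; a lower number here means that the compound crosses the layer more slowly, a higher number that the compound crosses the layer faster:
Compound 1 `Cc1cnc(NC(=O)c2cc(Oc3ccc(C#N)cc3)c3cc(C)oc3c2)cn1` gives 1.5 10^-6 cm/s
Compound 2 `CNC(=O)c1cnc(Oc2cc(C(=O)Nc3cnc(C)cn3)cc3oc(C)cc23)cn1` gives 20.9 10^-6 cm/s

Of these two compounds, compound 2 stands highest, and the gap to compound 1 lies beyond the scatter. Compound 3 `Cc1cnc(NC(=O)c2cc(Oc3cnc(C(=O)N4CCCCC4)cn3)c3cc(C)oc3c2)cn1` differs from compound 2 in one place piperidin-1-yl in place of methylamino on a carbonyl carbon with piperidin-1-yl in place of methylamino on a carbonyl carbon, so that methylcarbamoyl becomes (piperidin-1-yl)carbonyl.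

Among the measured compounds shown here, only one measured step bears on this, and only indirectly. It is large and beyond the scatter: a 14-fold higher number from compound 1 to compound 2 (1.14 log units; beyond the scatter) with 5-(methylcarbamoyl)pyrazin-2-yl in place of 4-cyanophenyl on an oxygen on an aromatic ring. For the measured compounds named here, no measured step changes the group on the carbonyl carbon, so the data give no firm direction for the new change. Compound 3 does not return to 4-cyanophenyl, so a fall to the level of compound 1 at 1.5 10^-6 cm/s is not expected. What is expected is a 1.3-fold lower number from compound 2 to compound 3 (0.12 log units; within the scatter) and no step beyond the scatter. In this assay the estimate for compound 3 is 16 10^-6 cm/s with an expected range of 6 10^-6 cm/s to 35 10^-6 cm/s.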

Compound 3, apparent permeability: 13.3 10^-6 cm/s
For compound 3 the middle estimate is 1.2-fold (0.08 log units) above the measured one; the range from low to high includes it.
By their numbers in this assay, from the lowest: compound 1; then compounds 3 and 2 (each within the scatter of the next).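

On the carbonyl carbon, where the compounds shown had so far offered no comparison, the exchange of methylamino for piperidin-1-yl gives, in this assay, a 1.6-fold lower number from compound 2 to compound 3 (0.20 log units; within the scatter), so compound 2 and compound 3 cannot be told apart in this read-out. At this place, then, a group of 2 heavy atoms with 1 hydrogen-bond donor can give way to one of 6 heavy atoms, with a six-membered non-aromatic ring and 0 hydrogen-bond donors, without a shift beyond the scatter, something the earlier step on the oxygen could not show. Nothing measured here offers an explanation for this result.

The size, the ring and the donor count all change together in this single step, so the compounds shown cannot separate their contributions, and any of them may matter or none. From the compounds shown here alone, it also remains open how far this tolerance extends, for instance to dimethylamino or morpholin-4-yl on the carbonyl carbon, or to a carboxylic acid in place of the whole amide.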